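The compounds below may be only part of what the source reports. "The series", "measured", "known", "first", "only" and "open" are said of these compounds alone.

Of the compounds shown here, three sharing one core have been tested in a functional assay on thoracic aorta (Rattus norvegicus, strain Wistar), with a stated time of 15 min (a lower number here means that less compound is needed, a higher number that more compound is needed for the effect), and a fourth is still to be measured. Compound 1 `COc1ccc(Cl)cc1C(C)NC(=O)NS(=O)(=O)c1ccccc1` carries a hydrogen on the amide-type nitrogen. In this assay compound 1 gives > 300000 nM, which is a limit of the assay and not a number. Compound 2 `CCOc1ccc(Br)cc1C(C)NC(=O)NS(=O)(=O)c1ccccc1` differs from compound 1 in the core; the difference between the two cores is not broken down here. In this assay compound 2 also reaches only a limit, > 300000 nM. Compound 3 `COc1ccc(Cl)cc1C(C)NC(=O)N(C)S(=O)(=O)c1ccccc1` arises from compound 1 through (methyl in place of hydrogen on an amide-type nitrogen). In this assay compound 3 gives 7200 nM. As far as these compounds go, the measured step is an at least 41-fold lower number from compound 1 to compound 3 (1.61 log units; beyond the scatter); its exact size stays open because the limit of > 300000 nM in this assay, at which 2 of the 3 values shown sit, marks the starting point.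

Compound 4 `CCOc1ccc(Br)cc1C(C)NC(=O)N(C)S(=O)(=O)c1ccccc1` arises from compound 2 through the same change, (methyl in place of hydrogen on an amide-type nitrogen), at a place described in the same words as for compound 3. Compound 4 has not yet been measured in this assay.

The step from compound 2 to compound 4 is expected to resemble the earlier one, the two changes being the same; the expected size is an at least 30-fold lower number from compound 2 to compound 4 (1.47 log units; beyond the scatter), though its lower bound cannot be stated sharply since compound 2 sits at a limit. This expectation rests on compound 3 and its value 7200 nM, since the core of compound 2 has not been measured with a methyl on that nitrogen. Compound 4 is therefore estimated at 10000 nM, with a likely range from 2500 nM to 60000 nM.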

Compound 4, half-maximal effective concentration: 19800 nM
Estimate against measurement, compound 4: 2.0-fold (0.30 log units) below; measured number inside the range.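

Methyl in place of hydrogen on the amide-type nitrogen again gives a large step in this assay, an at least 15-fold lower number from compound 2 to compound 4 (1.18 log units; beyond the scatter), and the direction matches the one seen on the core of compound 1. In both pairs, a compound that reaches only a limit of the assay gives way to one with a measured value, so within these two pairs the change carries from one core to the other. This does not show that the step has the same size on both cores, since the two can be compared only as bounds: the same change on two cores in this assay, an at least 41-fold lower number (1.61 log units; beyond the scatter) from compound 1 to compound 3 and an at least 15-fold lower number (1.18 log units; beyond the scatter) from compound 2 to compound 4; the limit leaves it open whether they differ. Neither step has a known exact size, and each remains only a minimum, as both start from the same limit, which is not a number: the limit of > 300000 nM in this assay, at which 2 of the 4 values shown sit.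

The compounds shown leave open whether an ethyl, a longer chain or a benzyl group on that nitrogen would behave as the methyl does, and whether a carboxylic acid or an amine at the end of such a chain would keep the effect. They also leave open whether the step would persist on a core in which the halogen or the alkoxy group alone is changed, since the two cores shown differ from each other without that difference being broken down.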